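This account rests on a few compounds, and the source may have more. Where it says the series, first, only, none or still open, it means among the compounds named here.

Compound 1 `O=C(CCCCCCc1ccccc1)c1ncc(-c2ccccc2F)o1` in an assay (Rattus norvegicus) for inhibition of Fatty-acid amide hydrolase 1 (Homo sapiens) (a lower number here means a stronger inhibitor, a higher number a weaker inhibitor), gives 110 nM. Compound 2 `COC(=O)c1ccc(-c2cnc(C(=O)CCCCCCc3ccccc3)o2)cc1` in this assay gives 40 nM.

Of the two numbers, compound 2 has the lower one, and compound 1 sits higher by a margin beyond the scatter. Compound 3 `NC(=O)c1ccc(-c2cnc(C(=O)CCCCCCc3ccccc3)o2)cc1` differs from compound 2 in one place: amino in place of methoxy on a carbonyl carbon. Within the data shown here, no step of this kind between measured compounds is known here, so the size can only be guessed; a small step, if any, is expected, with no clear direction beyond the scatter. For compound 3 the expected value in this assay is 35 nM, from 9 nM to 140 nM, which would mean a step of a 1.1-fold lower number from compound 2 to compound 3 (0.06 log units; within the scatter) that is expected to stay within the scatter.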

Compound 3, inhibition constant: 10 nM
The estimate for compound 3 lay 3.5-fold (0.54 log units) above the measured number; the range from low to high includes it.
By their numbers in this assay, from the lowest: compound 3; then compound 2; then compound 1.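

In this assay, the change from methoxycarbonyl to carbamoyl is not a silent one: amino in place of methoxy on the carbonyl carbon gives a 4.0-fold lower number from compound 2 to compound 3 (0.60 log units; beyond the scatter), so this site responds to the group on that carbonyl alone. With 4-carbamoylphenyl in place of 2-fluorophenyl on an aromatic carbon, the step reaches an 11-fold lower number from compound 1 to compound 3 (1.04 log units; beyond the scatter). No available evidence accounts for this result. Going by these compounds, whether the amide hydrogen matters stays open, as does how a carboxylic acid, an N-methyl amide or a nitrile would compare on the same aromatic carbon.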